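From an amino ester to a pyrrolidine ester

This account rests on a few compounds, and the source may have more. Where it says the series, first, only, none or still open, it means among the compounds named here.

Compound 1 `CC(=O)OCCNc1c(C(=O)NCc2ccc(F)cc2F)c(=O)n(O)c2ncccc12`: > 250000 nM
Compound 2 `COC(=O)CNc1c(C(=O)NCc2ccc(F)cc2F)c(=O)n(O)c2ncccc12`: > 250000 nM
Compound 3 `CCOC(=O)[C@@H]1CCCN1c1c(C(=O)NCc2ccc(F)cc2F)c(=O)n(O)c2ncccc12`: not yet measured

In an ADME assay on HOS cells (Homo sapiens) for cytotoxicity, read by a luciferase reporter and ATP content (on this read-out higher numbers stand for lower toxicity in this test and lower numbers for higher toxicity in this test), compound 2 gives > 250000 nM, which is a limit and not a number. Compound 1 gives > 250000 nM, also a limit. Neither compound has left (the limit of > 250000 nM in this assay, at which 2 of the 2 values shown sit).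

Compound 3 carries 2-(ethoxycarbonyl)pyrrolidin-1-yl in place of ((methoxycarbonyl)methyl)amino on an aromatic carbon. Among the measured compounds shown here, the only measured step, a step that the two limits leave unreadable from compound 1 to compound 2, gives no size to carry over. A modest move toward higher toxicity in this test, if any, is therefore expected, and the estimated step is an at least 1.6-fold lower number from compound 2 to compound 3 (0.22 log units; that floor lies within the scatter). Compound 3 is estimated at 150000 nM, with an expected range from 50000 nM to 250000 nM.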

Compound 3, half-maximal cytotoxic concentration: 18000 nM
Compound 3: the middle estimate sits 8.3-fold (0.92 log units) above what was measured; measured number below the stated range.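

In this assay, this aromatic carbon proves able to shift the read-out: 2-(ethoxycarbonyl)pyrrolidin-1-yl gives an at least 13-fold lower number from compound 2 to compound 3 (1.14 log units; beyond the scatter), and in place of (2-acetoxyethyl)amino it gives an at least 13-fold lower number from compound 1 to compound 3 (1.14 log units; beyond the scatter). The step between compound 1 and compound 2 cannot be read, and compound 3 alone gives a number rather than a limit: the limit of > 250000 nM in this assay, at which 2 of the 3 values shown sit.

The change brings in a ring and a defined stereocentre and loses the hydrogen-bond donor in one step, and the compounds shown do not separate these. From the compounds shown here alone, whether an unsubstituted pyrrolidine or a pyrrolidine bearing a carboxylic acid would give a similarly low number stays open.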